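Trifluoromethyl in place of propyl on the pyrimidine

The source may hold more compounds than are shown below. What is called first, only, known or untested is meant among the compounds shown, and "the series" means these compounds.

Measured compounds:
compound 1 `CC#CCn1c(N2CCC[C@@H](N)C2)nc2c1c(=O)n(CCCN1CCN(c3ncc(OC)cn3)CC1)c(=O)n2C`: 2260 nM
compound 2 `CC#CCn1c(N2CCC[C@@H](N)C2)nc2c1c(=O)n(CCCN1CCN(c3ncc(CCC)cn3)CC1)c(=O)n2C`: 1850 nM

In a functional assay on HEK293 cells for agonist activity at Glucose-dependent insulinotropic receptor (Homo sapiens), read by a luciferase reporter (a lower number here means that less compound is needed, a higher number that more compound is needed for the effect), compound 2 gives the lower of the two numbers, but the step of a 1.2-fold lower number from compound 1 to compound 2 (0.09 log units; within the scatter) is within the scatter, so the two compounds cannot be told apart. Compound 3 `CC#CCn1c(N2CCC[C@@H](N)C2)nc2c1c(=O)n(CCCN1CCN(c3ncc(C(F)(F)F)cn3)CC1)c(=O)n2C` carries the change (trifluoromethyl in place of propyl on an aromatic carbon). Going by the values given here, the only measured step at this position, a 1.2-fold lower number from compound 1 to compound 2 (0.09 log units; within the scatter), was within the scatter, so no step beyond the scatter is expected here either, and the step of a 1.0-fold lower number from compound 2 to compound 3 (0.01 log units; within the scatter) is estimated as essentially flat. For compound 3 the expected value in this assay is 1800 nM, with a range from 700 nM to 4500 nM.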

Compound 3, half-maximal effective concentration: 4020 nM
Compound 3: middle estimate off by 2.2-fold (0.35 log units), on the low side; the range from low to high includes it.
By their numbers in this assay, from the lowest: compounds 2, 1 and 3 (each within the scatter of the next, the first and the last beyond it).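

In this assay, this aromatic carbon now shows its first step beyond the scatter (a 2.2-fold higher number from compound 2 to compound 3 (0.34 log units; beyond the scatter)), so the position is not indifferent to every group placed there. Trifluoromethyl cannot be separated from methoxy, however (a 1.8-fold higher number from compound 1 to compound 3 (0.25 log units; within the scatter)). No evidence is available that accounts for the step from propyl to trifluoromethyl. Going by these compounds, whether an amine, a carboxylic acid or a longer chain at this carbon would shift the number in either direction remains open, as does whether any group here can bring it well below those of compound 1 and compound 2.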